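The source may hold more compounds than are shown below. What is called first, only, known or untested is meant among the compounds shown, and "the series" means these compounds.

Measured so far:
- compound 1, `NCCNC(=O)c1c(O)c2ccccc2n(-c2ccccc2)c1=O`, gives 7.9%
- compound 2, `NCCCCCCNC(=O)c1c(O)c2ccccc2n(-c2ccccc2)c1=O`, gives 28.1%
- compound 3, `Nc1ccccc1NC(=O)c1c(O)c2ccccc2n(-c2ccccc2)c1=O`, gives 34.7%

These numbers come from a functional assay, with a stated time of 60 min, tested at 0.5 mM; a higher number here means a stronger effect of the compound at the concentration tested, a lower number a weaker effect. Compound 2 stands second highest of the three, close to compound 3, where the gap a number 6.6 percentage points higher from compound 2 to compound 3 (within the scatter) is within the scatter, and clearly apart from compound 1, from which the step of a number 20.2 percentage points higher from compound 1 to compound 2 (beyond the scatter) is beyond the scatter.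

Compound 4, `O=C(CCCCC1CCSS1)NCCCCCCNC(=O)c1c(O)c2ccccc2n(-c2ccccc2)c1=O`, differs from compound 2 by a group of 11 heavy atoms (8 carbon, 1 oxygen, 2 sulfur; one five-membered non-aromatic ring with 2 hetero atoms) in place of a hydrogen atom, on an amine nitrogen. Going by the values given here, none of the measured steps alters that amine nitrogen itself. The step from compound 1 to compound 2 added chain atoms in this region and gave a number 20.2 percentage points higher from compound 1 to compound 2 (beyond the scatter), and the step of a number 26.8 percentage points higher from compound 1 to compound 3 (beyond the scatter) changed the group on the amide nitrogen; both were modest gains, but neither replaces an amine hydrogen with a larger group. Among the compounds with values here, with no direct precedent, the change to compound 4 is expected to move the number little, with wide uncertainty: a number 1.9 percentage points higher from compound 2 to compound 4 (within the scatter).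

Compound 4 is therefore estimated at 30%, between 10% and 55%.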

Compound 4, a percentage reported as activity, at one concentration (the size of the read-out at that concentration, not a potency): 29.5%
Estimate against measurement, compound 4: 0.5 percentage points above; low and high end bracket the measured number.
By their numbers in this assay, from the lowest: compound 1; then compounds 2, 4 and 3 (each within the scatter of the next).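

On the amine nitrogen of compound 2, a group of 11 heavy atoms (8 carbon, 1 oxygen, 2 sulfur) with one five-membered non-aromatic ring can take the place of a hydrogen atom, and this assay gives a number 1.4 percentage points higher from compound 2 to compound 4 (within the scatter). The earlier steps shown here changed the chain or the group on the amide nitrogen, whereas this one alters the amine nitrogen itself and shows that a large addition there leaves the read-out level at the concentration tested. No supporting measurement accounts for this result.

From the compounds shown here alone, it remains open whether a small acetyl group or a chain ending in a carboxylic acid on this nitrogen would give a similar number. Going by these compounds, the same group's effect on the 2-aminoethyl chain of compound 1 or the 2-aminophenyl group of compound 3 also remains open.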